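The compounds below may be only part of what the source reports. "The series", "measured", "known", "first", "only" and "open" are said of these compounds alone.

Measured in a functional assay on G-361 cells (Homo sapiens) for antiproliferative activity, with a stated time of 72 h; on this read-out lower numbers stand for stronger inhibition and higher numbers for weaker inhibition:
Compound 1 `Cc1cccc(CNc2ncnc3c2ncn3[C@@H]2O[C@H](CO)[C@@H](O)[C@H]2O)c1` gives > 166000 nM as a limit of the assay
Compound 2 `OC[C@H]1O[C@@H](n2cnc3c(NCc4ccc(Cl)cc4Cl)ncnc32)[C@H](O)[C@@H]1O` gives 128000 nM
Compound 3 `OC[C@H]1O[C@@H](n2cnc3c(NCc4cccc(O)c4O)ncnc32)[C@H](O)[C@@H]1O` gives 16900 nM

Compound 3 holds the lowest actual number in this assay (a 7.6-fold lower number from compound 2 to compound 3 (0.88 log units; beyond the scatter)). Compound 4 `OC[C@H]1O[C@@H](n2cnc3c(NCc4cc(O)cc(O)c4)ncnc32)[C@H](O)[C@@H]1O` differs from compound 3 (3,5-dihydroxyphenyl in place of 2,3-dihydroxyphenyl on a saturated chain carbon bound to a nitrogen on an aromatic ring), with 3,5-dihydroxyphenyl in place of 2,3-dihydroxyphenyl on a saturated chain carbon bound to a nitrogen on an aromatic ring. The measured steps at this place exchange the whole group (an at least 1.2-fold lower number from compound 1 to compound 2 (0.11 log units; that floor lies within the scatter); an at least 9.8-fold lower number from compound 1 to compound 3 (0.99 log units; beyond the scatter)), and none only relocates the hydroxyls, so they bear on it indirectly. Some of the gain of compound 3 (an at least 9.8-fold lower number from compound 1 to compound 3 (0.99 log units; beyond the scatter)) is expected to be lost. The expected step is a small one toward a higher number (a 2.4-fold higher number from compound 3 to compound 4 (0.37 log units; beyond the scatter)). For compound 4 the estimated value is 40000 nM (expected range 12000 nM to 130000 nM).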

Compound 4, half-maximal inhibitory concentration: > 166000 nM
Compound 4: a limit, no number; the forecaster's own chance of this, stated with the estimate: 25%; at least 4.1-fold (0.61 log units) between middle value and limit.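

Moving the hydroxyls from 2,3-dihydroxyphenyl to 3,5-dihydroxyphenyl, with the same atoms and the same donor and acceptor counts, gives in this assay an at least 9.8-fold higher number from compound 3 to compound 4 (0.99 log units; beyond the scatter), so at this position the placement of the hydroxyls matters, not only their presence. The other readable step, an at least 1.2-fold higher number from compound 2 to compound 4 (0.11 log units; that floor lies within the scatter), has a floor within the scatter, so it sets no order between the two groups, and the step between compound 1 and compound 4 cannot be read. Compound 4 gives only a limit, not a number: the limit of > 166000 nM in this assay, at which 2 of the 4 values shown sit.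

Going by these compounds, whether 3,4-dihydroxyphenyl or 2,3-dimethoxyphenyl at this place would keep the level of compound 3 remains open.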